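The source may hold more compounds than are shown below. What is called first, only, known or untested is meant among the compounds shown, and "the series" means these compounds.

Measured compounds:
compound 1, `C[C@@H](Cn1ccc(-c2ccc(C#N)c(Cl)c2)n1)NC(=O)c1cccc(OCC(O)CO)c1`: > 30000 nM
compound 2, `C[C@@H](Cn1ccc(-c2ccc(C#N)c(Cl)c2)n1)Nc1ccccc1`: > 30000 nM

Both figures come from a functional assay on CWR22R cells (Homo sapiens) for antiproliferative activity, read by CCK-8 assay, with a stated time of 6 days; a higher number here means a weaker inhibitor, a lower number a stronger inhibitor. For compound 1 the figure of > 30000 nM is a limit of this assay, not a number. For compound 2 the figure of > 30000 nM is likewise a limit of this assay, not a number. Among the measured compounds shown here, compound 2 thus has no measured number of its own to stand on; what the series shows so far is the limit of > 30000 nM in this assay, at which 2 of the 2 values shown sit, and no step between measured compounds can be computed from two limits.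

Compound 3, `Cc1ccnc(N[C@@H](C)Cn2ccc(-c3ccc(C#N)c(Cl)c3)n2)n1`, is not yet measured. The change from compound 2 is 4-methylpyrimidin-2-yl in place of phenyl on an amine nitrogen. The same difference, cut one bond further out, reads anilino to (4-methylpyrimidin-2-yl)amino.

For the measured compounds named here, with compound 2 known only as a limit, the measured data give no direction for the step; the step from compound 2 to compound 3 is expected as an at least 2.5-fold lower number from compound 2 to compound 3 (0.39 log units; beyond the scatter), read as a possible move toward stronger inhibition of uncertain size. Compound 3 is expected to give about 12000 nM in this assay, within a range from 1500 nM to 40000 nM, and a limit may again be all that is returned.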

Compound 3, half-maximal inhibitory concentration: 4760 nM
Estimate against measurement, compound 3: 2.5-fold (0.40 log units) above; the range from low to high includes it.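

On the amine nitrogen whose other neighbour is a saturated chain carbon, 4-methylpyrimidin-2-yl yields the only figure in this assay that is a number and not a limit: compound 3 gives 4760 nM. The step reads an at least 6.3-fold lower number from compound 2 to compound 3 (0.79 log units; beyond the scatter), which shows that activity in this series responds to the group on this nitrogen, and its size is only a bound, as the value of compound 2 is a limit. Compound 3 alone stands clear of what otherwise marks the compounds shown: the limit of > 30000 nM in this assay, at which 2 of the 3 values shown sit.

The change brings in a ring with 2 hetero atoms and a methyl group together, so the compounds shown do not separate the contribution of the ring nitrogens from that of the methyl group, and the true size of the step stays unknown. Unsubstituted pyrimidin-2-yl and 4-methylphenyl on the same nitrogen would divide the change into these two parts, and a longer chain in place of the methyl group would show whether the gain extends further at this position.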